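Difluoro to Dimethyl at the Limit of Clearance

The compounds below may be only part of what the source reports. "The series", "measured", "known", "first", "only" and "open" are said of these compounds alone.

In an ADME assay on microsomes from liver (Mus musculus) for metabolic stability, read by LC-MS, with a stated time of 40 min, tested at 0.5 uM (a lower number here means slower removal, a higher number faster removal of the compound), compound 1 `O=C(Nc1cccc(S(=O)(=O)C2CCCC2)c1)c1cccnc1N1CCC(F)(F)CC1` gives > 399 mL.min-1.g-1 as a limit of the assay and not a number. Compound 2 `CC(C)(C)NS(=O)(=O)c1cccc(NC(=O)c2cccnc2N2CCC3(CC2)CC3)c1` gives > 399 mL.min-1.g-1 as a limit too. Compound 3 `CC1(C)CCN(c2ncccc2C(=O)Nc2cccc(S(=O)(=O)C3CCCC3)c2)CC1` carries 4,4-dimethylpiperidin-1-yl in place of 4,4-difluoropiperidin-1-yl on an aromatic carbon. Among the compounds with values here, no measured pair shows what this swap does. The estimated step that the limit leaves unreadable from compound 1 to compound 3 is expected to stay within the usual scatter, with no clear direction. For compound 3 the expected value is 420 mL.min-1.g-1 with an estimated range from 250 mL.min-1.g-1 to 800 mL.min-1.g-1 and it may well turn out to be a limit again.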

Compound 3, intrinsic clearance in microsomes: > 399 mL.min-1.g-1
Compound 3: no number, only a limit; the forecaster's own chance of this, stated with the estimate: 80%; the middle value is on the limit's open side.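

The swap from compound 1 to compound 3 gives no readable step in this assay, since both values are limits of the assay and not numbers: the limit of > 399 mL.min-1.g-1 in this assay, at which 3 of the 3 values shown sit.

On these data alone, how fast compound 1 and compound 3 are actually removed, and whether they differ at all, stays open.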